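From 3,5-difluorophenyl to 2,3-dichlorophenyl on a shared core

The source may report more compounds than this note shows. Statements on the series, on what has been measured and on what is new or still open speak of the compounds shown alone.

Measured so far in a functional assay on HL-60 cells (Homo sapiens) for inhibition, read by MTT assay, with a stated time of 48 h, tested at 10 uM; a higher number here means more inhibition of growth at the concentration tested, a lower number less inhibition of growth
Compound 1 `Cc1oc2c([C@H]3CCN(C)C[C@H]3O)c(O)cc(O)c2c(=O)c1C(O)c1cccc(Cl)c1` gives 22%
Compound 2 `Cc1oc2c([C@H]3CCN(C)C[C@H]3O)c(O)cc(O)c2c(=O)c1C(O)c1ccc(F)c(Br)c1` gives 25%
Compound 3 `Cc1oc2c([C@H]3CCN(C)C[C@H]3O)c(O)cc(O)c2c(=O)c1C(O)c1cc(F)cc(F)c1` gives 30%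

Compound 3 is not set apart from the other two, as the data show a number 5 percentage points higher from compound 2 to compound 3 (within the scatter) and a number 3 percentage points higher from compound 1 to compound 2 (within the scatter) as well. Compound 4 `Cc1oc2c([C@H]3CCN(C)C[C@H]3O)c(O)cc(O)c2c(=O)c1C(O)c1cccc(Cl)c1Cl` carries 2,3-dichlorophenyl in place of 3,5-difluorophenyl on a saturated chain carbon bound to an aromatic carbon and an oxygen on a saturated carbon on a saturated chain carbon bound to an aromatic carbon and an oxygen on a saturated carbon. The measured steps all exchange the substituted phenyl group at that same place, and even a number 8 percentage points higher from compound 1 to compound 3 (within the scatter) does not pass the scatter, so no step beyond the scatter is expected in this assay here. Within the data shown here, no measured compound carries 2,3-dichlorophenyl, so the expected range stays wide. The estimated step is a number 4 percentage points lower from compound 3 to compound 4 (within the scatter) and remains an expectation. For compound 4 the estimated value is 26% with an expected range from 14% to 38% in this read-out.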

Compound 4, percent growth inhibition at one concentration: 12%
Beside the measured number, compound 4's estimate is 14 percentage points above it, and the stated range ends above it.
By their numbers in this assay, from the lowest: compounds 4, 1, 2 and 3 (each within the scatter of the next, the first and the last beyond it).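

In this assay the substituted phenyl group on a saturated chain carbon bound to an aromatic carbon and an oxygen on a saturated carbon now gives steps beyond the scatter, which no earlier exchange there did: a number 18 percentage points lower from compound 3 to compound 4 (beyond the scatter) and a number 13 percentage points lower from compound 2 to compound 4 (beyond the scatter). The single change of chloro in place of hydrogen on an aromatic carbon gives a number 10 percentage points lower from compound 1 to compound 4 (within the scatter) and stays within the scatter, so that one atom alone is not shown to matter. Nothing available explains these steps.

The compounds shown leave open how an amine or a carboxylic acid on the phenyl ring at this place, or a longer chain in place of that ring, would read in this assay.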